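The source may report more compounds than this note shows. Statements on the series, on what has been measured and on what is new or still open speak of the compounds shown alone.

Compound 1 `CCOC(=O)Nc1nc(=O)n(C2O[C@H](C(=O)O)[C@@H](O)[C@H]2O)cc1F`: 0.16 ug/mL
Compound 2 `CCCCCOC(=O)Nc1nc(=O)n(C2O[C@H](C(=O)O)[C@@H](O)[C@H]2O)cc1F`: 0.03 ug/mL

Going by the values given here, in a functional assay on SK-MEL-2 cells (Homo sapiens) for inhibition (a higher number here means a weaker inhibitor, a lower number a stronger inhibitor), compound 2 gives 0.03 ug/mL, the lower of the two numbers measured so far. Compound 3 `C=CCOC(=O)Nc1nc(=O)n(C2O[C@H](C(=O)O)[C@@H](O)[C@H]2O)cc1F` has not yet been measured, and it carries allyloxycarbonyl in place of pentyloxycarbonyl: vinyl in place of butyl on a saturated chain carbon bound to an oxygen next to a carbonyl group. Among the compounds with values here, the one measured step that bears on this change is a 5.3-fold lower number from compound 1 to compound 2 (0.73 log units; beyond the scatter), with propyl in place of hydrogen on the chain. The allyl chain is shorter than pentyl, so part of that step is expected to be lost. The expected step, towards a higher number, is a 3.0-fold higher number from compound 2 to compound 3 (0.48 log units; beyond the scatter). For compound 3 the estimated value is 0.09 ug/mL, within an expected range of 0.035 ug/mL to 0.22 ug/mL.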

Compound 3, half-maximal inhibitory concentration: 0.008 ug/mL
Estimate against measurement, compound 3: 11-fold (1.05 log units) above; the measured number lies below the stated range.
By their numbers in this assay, from the lowest: compound 3; then compound 2; then compound 1.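

In this assay, the shorter allyl chain does not give up the gain seen with pentyl: vinyl in place of butyl gives a lower number (a 3.8-fold lower number from compound 2 to compound 3 (0.57 log units; beyond the scatter)), and the change from the ethyl compound is large (a 20-fold lower number from compound 1 to compound 3 (1.30 log units; beyond the scatter)). Chain length alone therefore does not order the numbers at this position, since compound 2 fits a longer-is-lower reading and compound 3 goes against it. Nothing available explains this result.

The compounds shown leave open whether the double bond itself matters, which a saturated propyl chain would test. On these data alone, how a propargyl or benzyl group would behave here also remains open.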